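Working notes: from compound 3 to compound 4

The source may report more compounds than this note shows. Statements on the series, on what has been measured and on what is new or still open speak of the compounds shown alone.

Values in a functional assay on Jurkat cells (Homo sapiens); on this read-out lower numbers stand for stronger inhibition and higher numbers for weaker inhibition:
- compound 1 `C[C@H](NC(=O)C(=O)NCc1ccc(Cl)cc1)C(=O)N[C@@H](CC(=O)O)C(=O)COc1c(F)c(F)cc(F)c1F`: 8.4 nM
- compound 2 `C[C@H](NC(=O)C(=O)NCC1CCCCC1)C(=O)N[C@@H](CC(=O)O)C(=O)COc1c(F)c(F)cc(F)c1F`: 19 nM
- compound 3 `Cc1ccc(CNC(=O)C(=O)N[C@@H](C)C(=O)N[C@@H](CC(=O)O)C(=O)COc2c(F)c(F)cc(F)c2F)c(C)c1`: > 10000 nM, a limit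

Compound 3 gives no number, only a limit: the limit of > 10000 nM in this assay, at which 1 of the 3 values shown sits. Compound 4 `C[C@H](NC(=O)C(=O)NCc1c(Cl)cccc1Cl)C(=O)N[C@@H](CC(=O)O)C(=O)COc1c(F)c(F)cc(F)c1F` differs from it at one place: 2,6-dichlorophenyl in place of 2,4-dimethylphenyl on a saturated chain carbon bound to an amide-type nitrogen. Three measured steps at this same place bear on the change. The first is modest: a 2.3-fold higher number from compound 1 to compound 2 (0.35 log units; beyond the scatter). The other two are large: an at least 1100-fold higher number from compound 1 to compound 3 (3.07 log units; beyond the scatter) and an at least 520-fold higher number from compound 2 to compound 3 (2.72 log units; beyond the scatter). The 2,6-dichlorophenyl group carries chlorine, as does the 4-chlorophenyl group of compound 1 at 8.4 nM. A large step to a lower number is therefore expected in this assay: an at least 200-fold lower number from compound 3 to compound 4 (2.30 log units; beyond the scatter). For compound 4 the expected value is 50 nM, with an estimated range of 5 nM to 3000 nM.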

Compound 4, half-maximal inhibitory concentration: 110 nM
Compound 4: middle estimate off by 2.2-fold (0.34 log units), on the low side, and the stated range covers the measured number.
By their numbers in this assay, from the lowest: compound 1; then compound 2; then compound 4. At a limit, above all of these: compound 3.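

Compound 3 stands only as a limit: the limit of > 10000 nM in this assay, at which 1 of the 4 values shown sits.

Measured against that limit, 2,6-dichlorophenyl restores a readable value in this assay, an at least 90-fold lower number from compound 3 to compound 4 (1.95 log units; beyond the scatter), so two substituents on the phenyl ring at this place do not by themselves abolish inhibition. The group still ranks behind both earlier groups, with a 13-fold higher number from compound 1 to compound 4 (1.12 log units; beyond the scatter) and a 5.8-fold higher number from compound 2 to compound 4 (0.76 log units; beyond the scatter).

As far as these compounds go, whether the loss in compound 3 follows from the methyl groups or from their arrangement stays open. 2,4-Dichlorophenyl and 4-methylphenyl at this place would separate the two.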